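From ethyl(methyl)amino to amino on the carbonyl carbon

The compounds below may be only part of what the source reports. "The series", "measured", "known", "first", "only" and "open" are said of these compounds alone.

Values in a functional assay on the whole organism with Mus musculus as the target; on this read-out higher numbers stand for an effect only at larger amounts of compound and lower numbers for an effect already at smaller amounts:
Compound 1 `CN(C)C(=O)/C=C1\CCc2ccc(F)cc21`: > 100 mg/kg, a limit of the assay
Compound 2 `NC(=O)/C=C1\CCc2cc(F)c(F)cc21`: 64 mg/kg
Compound 3 `CCN(C)C(=O)/C=C1\CCc2ccc(F)cc21`: 100 mg/kg
Compound 4 `NC(=O)/C=C1\CCc2ccc(F)cc21`: not yet measured

In this assay compound 3 at 100 mg/kg lies within the scatter of compound 2 at 64 mg/kg. The reading for compound 1 is only a limit.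

The next change is amino in place of ethyl(methyl)amino on a carbonyl carbon, which puts amino in place of ethyl(methyl)amino on a carbonyl carbon. The one measured step among these amides is a number no higher from compound 1 to compound 3 (the limit leaves the size open), so it gives no usable size. The closest guide is compound 2, which also carries amino on the carbonyl carbon and gives 64 mg/kg, although its core is not the same as that of compound 4. A modest move towards a lower number is therefore expected, not clearly beyond the scatter. The expected step is a 1.7-fold lower number from compound 3 to compound 4 (0.22 log units; within the scatter). For compound 4 the estimated value is 60 mg/kg, with an expected range of 25 mg/kg to 130 mg/kg.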

Compound 4, dose for half-maximal effect: 56 mg/kg
The estimate for compound 4 lay 1.1-fold (0.03 log units) above the measured number; low and high end bracket the measured number.
By their numbers in this assay, from the lowest: compounds 4, 2 and 3 (each within the scatter of the next).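

In this assay, amino in place of ethyl(methyl)amino on a carbonyl carbon, now seen on one shared core, leaves the reading within the scatter (a 1.8-fold lower number from compound 3 to compound 4 (0.25 log units; within the scatter)). Hydrogen in place of fluoro on an aromatic carbon also stays within the scatter (a 1.1-fold lower number from compound 2 to compound 4 (0.06 log units; within the scatter)), so the fluoro that compound 2 carries and compound 4 lacks makes no readable difference in this assay. For amino in place of dimethylamino only a floor can be read (an at least 1.7-fold lower number from compound 1 to compound 4 (0.25 log units; that floor lies within the scatter)), since compound 1 is held only at a limit: the limit of > 100 mg/kg in this assay, at which 1 of the 4 values shown sits.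

Open, on these data alone, is what a longer chain on the amide nitrogen, a morpholine ring on the carbonyl carbon or a carboxylic acid in place of the amide would give. Also open, as far as these compounds go, is whether chloro in place of fluoro on the aromatic carbon would give a step beyond the scatter.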